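A few compounds are considered here, and "the series" means these few. Any claim that something is new, unique, unknown or untested is made for them only; others in the source may bear on it.

Measured in a functional assay on A-375 cells (Homo sapiens) for antiproliferative activity, read by MTT assay, with a stated time of 24 h, tested at 1.23 ug/mL; on this read-out higher numbers stand for a stronger effect at the one concentration tested and lower numbers for a weaker effect:
compound 1 `CCc1ccc2nc(C(=O)Nc3c(F)cc(-c4cccc(F)c4)cc3F)c(C)c(O)c2c1` gives 12.3%
compound 2 `Cc1c(C(=O)Nc2c(F)cc(-c3cccc(F)c3)cc2F)nc2ccc(F)cc2c1O` gives 2.34%
compound 3 `CCOc1ccc2nc(C(=O)Nc3c(F)cc(-c4cccc(F)c4)cc3F)c(C)c(O)c2c1` gives 2.96%

Compound 2 has the lowest of the three numbers, but its neighbours lie within the scatter: a number 0.6 percentage points higher from compound 2 to compound 3 (within the scatter) and, the other way, a number 10 percentage points lower from compound 1 to compound 2 (within the scatter). Compound 4 `Cc1c(C(=O)Nc2c(F)cc(-c3cccc(F)c3)cc2F)nc2ccc(F)cc2c1C(=O)O` differs from compound 2 by carboxy in place of hydroxy on an aromatic carbon. Among the compounds with values here, none of the measured steps touches this change; all three concern a substituent on another aromatic carbon, and all were within the scatter, including a number 9.3 percentage points lower from compound 1 to compound 3 (within the scatter). The series therefore gives no ground to expect a step beyond the scatter in this assay, and the expected step of a number 0.7 percentage points higher from compound 2 to compound 4 (within the scatter) is set at about nothing. Compound 4 is thus expected to give 3%, with a range of 0% to 13%.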

Compound 4, a percentage reported as inhibition, at one concentration (the size of the read-out at that concentration, not a potency): 16.3%
Estimate against measurement, compound 4: 13.3 percentage points below; measured number outside the range, above it.
By their numbers in this assay, from the lowest: compounds 2, 3, 1 and 4 (each within the scatter of the next, the first and the last beyond it).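

In this assay, the aromatic carbon opposite the ring nitrogen responds to its substituent: carboxy in place of hydroxy brings a number 14 percentage points higher from compound 2 to compound 4 (beyond the scatter), the only step shown beyond the scatter. The earlier steps all concerned a substituent on another aromatic carbon and stayed within the scatter, so this is the first position shown to shift the read-out. No measured evidence bears on the origin of this step.

From the compounds shown here alone, whether a methyl ester or an amine at this position would keep the step remains open. So does whether the step holds with ethyl or ethoxy in place of the fluoro on the other aromatic carbon.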